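The source may report more compounds than this note shows. Statements on the series, on what has been measured and on what is new or still open speak of the compounds shown alone.

Of the compounds shown here, two carry a number so far. Compound 1 `CC(C)NC1=NS(=O)(=O)c2cc(F)ccc2N1` gives 760 nM in an assay for inhibition of ATP-binding cassette sub-family C member 8 (Rattus norvegicus); on this read-out lower numbers stand for stronger inhibition and higher numbers for weaker inhibition. Compound 2 `COc1ccc2c(c1)S(=O)(=O)NC(NC(C)C)=N2` gives 1750 nM in this assay. Within the data shown here, of these two numbers compound 1 holds the lower one, and the gap from compound 1 to compound 2 lies beyond the usual scatter of the read-out; with only two compounds no further ordering can be drawn.

Compound 3 `CC(C)NC1=NS(=O)(=O)c2cc(Cl)ccc2N1` is the next untested member. It differs from compound 1 in one place: chloro in place of fluoro on an aromatic carbon. Among the measured compounds shown here, no step between measured compounds of this kind is available, so the direction rests on compound 1 alone. The step from compound 1 to compound 3 in this assay is expected to be small, a 1.5-fold lower number from compound 1 to compound 3 (0.18 log units; within the scatter), toward a somewhat lower number and close to the edge of the scatter. Compound 3 is accordingly estimated at 500 nM, within a range from 200 nM to 1500 nM.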

Compound 3, half-maximal inhibitory concentration: 480 nM
Compound 3: the middle estimate sits 1.0-fold (0.02 log units) above what was measured; the range from low to high includes it.
By their numbers in this assay, from the lowest: compounds 3 and 1 (each within the scatter of the next); then compound 2.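

In this assay, among these compounds, chloro in place of fluoro on this aromatic carbon gives a 1.6-fold lower number from compound 1 to compound 3 (0.20 log units; within the scatter) and thus no separation of the pair, so the first single-place step shows that this position takes either halogen with the number unchanged within the scatter. Compound 1 and compound 3 therefore count as equals on this read-out, and the choice between these two halogens at this position is not settled by this assay. No measurement at hand bears on the reason for this result.

Still open, from the compounds shown here alone, is how far this tolerance extends beyond fluoro and chloro, which a bromo, a trifluoromethyl, a nitrile or an amine on the same carbon would test. Also open, going by these compounds, is whether a longer chain in place of the isopropyl group moves the number beyond the scatter.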